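Catechol methylation on two amide linkers in a kinase series

The source may report more compounds than this note shows. Statements on the series, on what has been measured and on what is new or still open speak of the compounds shown alone.

The series pairs a sulfonylated diamine core with a phenol-bearing acyl arm. Compound 1 `O=C(/C=C/c1ccc(O)c(O)c1)N1CCCN(S(=O)(=O)c2cccc3cnccc23)CC1` carries an unsaturated arm on a seven-membered diamine; compound 3 `COc1cc(/C=C/C(=O)N2CCCN(S(=O)(=O)c3cccc4cnccc34)CC2)ccc1O` differs from it only by methyl in place of hydrogen on an oxygen on an aromatic ring. Compound 2 `O=C(CCc1ccc(O)c(O)c1)N1CCN(S(=O)(=O)c2cccc3cnccc23)CC1` has a saturated arm on a six-membered diamine, and compound 4 `COc1cc(CCC(=O)N2CCN(S(=O)(=O)c3cccc4cnccc34)CC2)ccc1O`, not yet measured, stands to compound 2 as compound 3 stands to compound 1, the difference being (methyl in place of hydrogen on an oxygen on an aromatic ring). The difference between the cores of compound 1 and compound 2 is not broken down here.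

In an assay on isolated protein for inhibition of Rho-associated protein kinase 2 (Homo sapiens), read by 33P incorporation, with a stated time of 30 min, in the presence of a further agent that is not named here (a lower number here means a stronger inhibitor, a higher number a weaker inhibitor), compound 1 gives 2130 nM and compound 3 gives 2610 nM, so the methylation step reads a 1.2-fold higher number from compound 1 to compound 3 (0.09 log units; within the scatter). In this assay compound 2 gives 320 nM, the lowest of the three numbers, with both other compounds beyond the scatter from it.

The place of the change is the same for both pairs, so the same change is now read on the core of compound 2. Because a 1.2-fold higher number from compound 1 to compound 3 (0.09 log units; within the scatter) stays within the scatter, the step from compound 2 to compound 4 in this assay is expected to be small as well, a 1.2-fold higher number from compound 2 to compound 4 (0.07 log units; within the scatter). Compound 4 is therefore estimated at 380 nM in this assay, with a likely range from 180 nM to 800 nM.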

Compound 4, half-maximal inhibitory concentration: > 10000 nM
Compound 4: only a limit was reported; the forecaster's own chance of this, stated with the estimate: 3%; middle value at least 26-fold (1.42 log units) from the limit.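

In this assay compound 4 gives > 10000 nM, which is a limit of the assay and not a number. The step of an at least 31-fold higher number from compound 2 to compound 4 (1.49 log units; beyond the scatter) is out of line with the step read on the unsaturated arm and seven-membered diamine, so in this series the change of hydroxy to methoxy does not carry from one core to the other with its size intact: the same change on two cores in this assay, a 1.2-fold higher number (0.09 log units; within the scatter) from compound 1 to compound 3 and an at least 31-fold higher number (1.49 log units; beyond the scatter) from compound 2 to compound 4, at least 25-fold (1.40 log units) apart, beyond the scatter of two such steps. Not shown is which part of the difference between compound 1 and compound 2 goes with this, the saturated arm or the six-membered diamine, since the two change together there, and not shown either is how far the step extends, since it rests on a limit: the limit of > 10000 nM in this assay, at which 1 of the 4 values shown sits.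

Open, going by these compounds, is whether the saturated arm on the seven-membered diamine, or the unsaturated arm on the six-membered diamine, would behave like compound 2 or like compound 1 when the same methyl enters. Also open, on these data alone, is whether the drop on the core of compound 2 is tied to methyl alone, or would also follow an ethyl on that oxygen or an amine in place of that hydroxy.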